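The compounds below may be only part of what the source reports. "The series", "measured", "known", "first", "only" and "open" are said of these compounds alone.

Three compounds share one core and carry a hydroxamic acid; they were tested in a functional assay on MGC-803 cells (Homo sapiens) for antiproliferative activity, read by MTT assay, with a stated time of 72 h; a lower number here means a stronger inhibitor, a higher number a weaker inhibitor. Compound 1 `Cc1cccc(-c2nc(CNc3ccc(C(=O)NO)cc3)n(-c3ccccc3)n2)c1` gives 8710 nM in this assay. Compound 2 `O=C(NO)c1ccc(NCc2nc(-c3ccccc3)nn2-c2ccccc2Cl)cc1` gives 9630 nM, and compound 3 `Cc1cccc(-n2nc(-c3ccccc3)nc2CNc2ccc(C(=O)NO)cc2)c1` gives 13200 nM; both of these values lie within the scatter of the value of compound 1, so no order among the three can be read from the numbers.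

Compound 4 `O=C(NO)c1ccc(NCc2nc(-c3ccccc3Cl)nn2-c2ccccc2)cc1` is not yet measured. It differs from compound 1 in one place: 2-chlorophenyl in place of 3-methylphenyl on an aromatic carbon.

Among the measured compounds shown here, the only measured step that bears on this exchange runs the other way, and on a different position: a 1.4-fold higher number from compound 2 to compound 3 (0.14 log units; within the scatter). Read in reverse, it hints at a slightly lower number when 2-chlorophenyl replaces 3-methylphenyl, but that step was itself within the scatter, and the place of the change here is not the same. Compound 4 is therefore expected to sit close to compound 1, with the step of a 1.2-fold lower number from compound 1 to compound 4 (0.06 log units; within the scatter) not reaching beyond the scatter. Compound 4 is estimated at 7500 nM, with a range from 3500 nM to 16000 nM.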

Compound 4, half-maximal inhibitory concentration: > 20000 nM
Compound 4: no number, only a limit; the forecaster's own chance of this, stated with the estimate: 5%; at least 2.6-fold (0.42 log units) between middle value and limit.
By their numbers in this assay, from the lowest: compounds 1, 2 and 3 (each within the scatter of the next). At a limit, above all of these: compound 4.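

On this aromatic carbon, between two ring nitrogen atoms, the exchange of 3-methylphenyl for 2-chlorophenyl gives an at least 2.2-fold higher number from compound 1 to compound 4 (0.36 log units; beyond the scatter). The earlier compounds shown here did not show such a step: the same two groups exchanged on an aromatic nitrogen, in the other direction, give a 1.4-fold higher number from compound 2 to compound 3 (0.14 log units; within the scatter), so the result of the exchange depends on which ring atom carries it. The entry for compound 4 in this assay is a limit and not a number, so the step has a lower bound but no known size: the limit of > 20000 nM in this assay, at which 1 of the 4 values shown sits.

The compounds shown leave open whether the chlorine itself or its place on the phenyl ring decides the outcome. Compounds with 3-chlorophenyl or 2-methylphenyl on this aromatic carbon would separate the two.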